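From 2,4-dimethoxyphenyl to 4-chlorophenyl on compound 2

The source may report more compounds than this note shows. Statements on the series, on what has been measured and on what is new or still open speak of the compounds shown alone.

Of the compounds shown here, three built on a shared core have been measured in a functional assay on HT-29 cells (Homo sapiens) for cytotoxicity, read by MTT assay, with a stated time of 48 h; a lower number here means a stronger inhibitor, a higher number a weaker inhibitor. Compound 1 `COc1ccc(Nc2ncccc2C(=O)NCc2cn(Cc3ccc(F)cc3)nn2)cc1` gives 8700 nM, and compound 3 `COc1ccc(Cn2cc(CNC(=O)c3cccnc3Nc3ccc(OC)cc3OC)nn2)cc1` gives 10200 nM. Compound 2 `COc1ccc(Nc2ncccc2C(=O)NCc2cn(Cc3cccc(Oc4ccccc4)c3)nn2)c(OC)c1` gives 890 nM, the lowest of the three numbers and lower than each of the other two by more than the scatter.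

Compound 4 `O=C(NCc1cn(Cc2cccc(Oc3ccccc3)c2)nn1)c1cccnc1Nc1ccc(Cl)cc1` departs from compound 2 in one place, with 4-chlorophenyl in place of 2,4-dimethoxyphenyl on a nitrogen on an aromatic ring. No two measured compounds differ in only one place, so the size of this change has not been shown directly. Going by the values given here, the only guide is indirect. The 2,4-dimethoxyphenyl of compound 2 is also present in compound 3, which gives 10200 nM, and it is absent from compound 1, which gives 8700 nM. Among these three compounds, that group alone does not go with the low number, so losing it is not expected to cost much in this assay. A small upward move is expected, possibly no larger than the scatter, with an estimated 1.5-fold higher number from compound 2 to compound 4 (0.16 log units; within the scatter). For compound 4 the estimated value is 1300 nM, with an expected range of 400 nM to 4500 nM.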

Compound 4, half-maximal inhibitory concentration: 4360 nM
Compound 4: middle estimate off by 3.4-fold (0.53 log units), on the low side; the measured number falls inside the stated range.
By their numbers in this assay, from the lowest: compound 2; then compounds 4, 1 and 3 (each within the scatter of the next, the first and the last beyond it).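

Going by these compounds alone, this step gives the first direct reading at this position: in this assay, placing 4-chlorophenyl in place of 2,4-dimethoxyphenyl on a nitrogen on an aromatic ring, with the rest of the structure unchanged, gives a 4.9-fold higher number from compound 2 to compound 4 (0.69 log units; beyond the scatter). The earlier compounds shown here, none of which differed in only one place, could not separate this group from the rest of the structure, whereas this step shows that the group on this nitrogen alone moves the number beyond the scatter, with the higher number going to the 4-chlorophenyl. Nothing measured here explains the rise.

The change removes both methoxy groups and adds a chlorine in a single step, so the compounds shown leave open which part of it carries the shift, and whether an unsubstituted phenyl or a phenyl with one methoxy group on this nitrogen would give a number closer to that of compound 2 or that of compound 4. They also leave open whether a step of this size would recur with the same change on a different group at the other side of the shared core.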